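A few compounds are considered here, and "the series" means these few. Any claim that something is new, unique, unknown or untested is made for them only; others in the source may bear on it.

Measured in a functional assay on MCF7 cells (Homo sapiens) for inhibition, read by MTT assay, with a stated time of 72 h; a lower number here means a stronger inhibitor, a higher number a weaker inhibitor:
compound 1, `COc1cc(NC(C)CCCNC(=O)Nc2ccc(F)cc2)c2ncccc2c1`: 26000 nM
compound 2, `COc1cc(NC(C)CCCNC(=O)NNC(=O)Nc2cccc(C(F)(F)F)c2)c2ncccc2c1`: 190 nM
compound 3, `COc1cc(NC(C)CCCNC(=O)NNC(=O)Nc2cc(C(F)(F)F)cc(C(F)(F)F)c2)c2ncccc2c1`: 2400 nM

Among these three, compound 1 stands at the highest number, well apart from compound 3 and further still from compound 2. Among the compounds with values here, the only measured step between close neighbours, a 13-fold higher number from compound 2 to compound 3 (1.10 log units; beyond the scatter), concerns a trifluoromethyl entering on an aromatic carbon in a different pair and says nothing about an exchange at the fluoro-bearing carbon of compound 1.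

Compound 4, `COc1cc(NC(C)CCCNC(=O)Nc2ccc(O)cc2)c2ncccc2c1`, differs from compound 1 by hydroxy in place of fluoro on an aromatic carbon. Within the data shown here, no measured step bears on this exchange, so the size of the step in this assay cannot be read from the data; a change within the scatter, in either direction, is the most that is expected. Compound 4 is therefore expected to give about 20000 nM, between 6000 nM and 60000 nM. That estimate means a 1.3-fold lower number from compound 1 to compound 4 (0.11 log units; within the scatter), a step expected to remain within the scatter.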

Compound 4, half-maximal inhibitory concentration: 5200 nM
The estimate for compound 4 lay 3.8-fold (0.59 log units) above the measured number, and the stated range ends above it.
By their numbers in this assay, from the lowest: compound 2; then compound 3; then compound 4; then compound 1.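

Hydroxy in place of fluoro on this aromatic carbon gives a 5.0-fold lower number from compound 1 to compound 4 (0.70 log units; beyond the scatter) in this assay, so the position para to the large group responds to the exchange of a single heavy atom. Within the data shown here, the earlier compounds showed only a trifluoromethyl step on a different aryl group, and this is the first measured change at this carbon. Nothing available on the compounds explains the step. Going by these compounds, whether an amine or a methoxy at this carbon would match hydroxy remains open. So does whether a carboxylic acid there would move the number further.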